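The compounds below may be only part of what the source reports. "The series", "measured", "known", "first", "only" and "open" are said of these compounds alone.

Measured compounds: compound 1 `CCCCCCCCc1ccc(OCC(=O)Cn2nnc(-c3ccccc3)n2)cc1` gives 24 nM in an assay on microsomes from brain for inhibition of Fatty-acid amide hydrolase 1 (Rattus norvegicus), read by fluorescence and HPLC, with a stated time of 60 min; on this read-out lower numbers stand for stronger inhibition and higher numbers for weaker inhibition; compound 2 `CCCCCCCCc1ccc(OCC(=O)Cn2nnnc2C(=O)OC)cc1` gives 1000 nM; compound 3 `CCCCCCCCc1ccc(OCC(=O)Cn2nnnc2C(=O)OCC)cc1` gives 940 nM.

Compound 1 gives the lowest of the three numbers, and the difference between its core and the core of compound 2 is not broken down here. Between compound 2 and compound 3 the change is methyl in place of hydrogen on a saturated chain carbon bound to an oxygen next to a carbonyl group, and the step is a 1.1-fold lower number from compound 2 to compound 3 (0.03 log units; within the scatter). Compound 4 `CCCCCCCCc1ccc(OC(C)C(=O)Cn2nnc(-c3ccccc3)n2)cc1` is not yet measured; it differs from compound 1 by methyl in place of hydrogen on a saturated chain carbon bound to a carbonyl carbon and an oxygen on an aromatic ring. This is the same kind of change as that from compound 2 to compound 3, but the place differs: there it sits on a saturated chain carbon bound to an oxygen next to a carbonyl group, here on a saturated chain carbon bound to a carbonyl carbon and an oxygen on an aromatic ring. Because the step of a 1.1-fold lower number from compound 2 to compound 3 (0.03 log units; within the scatter) is within the scatter, a step of similar size is expected for compound 4, namely a 1.7-fold higher number from compound 1 to compound 4 (0.22 log units; within the scatter), with a little margin for the different place. Compound 4 is estimated at 40 nM, between 12 nM and 150 nM.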

Compound 4, half-maximal inhibitory concentration in the Fatty-acid amide hydrolase 1 assay: 24 nM
For compound 4 the middle estimate is 1.7-fold (0.22 log units) above the measured one; measured number inside the range.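

In the Fatty-acid amide hydrolase 1 assay methyl in place of hydrogen gives no change at the digits printed from compound 1 to compound 4 (within the scatter), and set beside the earlier step, the change carries from one core to the other with no difference beyond the scatter: the same change on two cores in the Fatty-acid amide hydrolase 1 assay, a 1.1-fold lower number (0.03 log units; within the scatter) from compound 2 to compound 3 and no change at the digits printed (within the scatter) from compound 1 to compound 4, 1.1-fold (0.03 log units) apart, within the scatter of two such steps. This does not show that the same would hold on any other core, and the two steps sit at different places. In a physicochemical assay for lipophilicity, read by HPLC, tested at 5 mM (on this read-out higher numbers stand for higher lipophilicity and lower numbers for lower lipophilicity), compound 1 gives 8. In the physicochemical assay compound 4 gives > 8, which is a limit and not a number, so the step there cannot be read: the limit of > 8 in the physicochemical assay, at which 1 of the 2 values shown sits.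

The compounds shown leave open what an ethyl group or a longer chain on the same saturated chain carbon would do. On these data alone, an amine or a carboxylic acid there remains equally open.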